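Working notes: from compound 2 to compound 4

The source may hold more compounds than are shown below. What is called first, only, known or untested is meant among the compounds shown, and "the series" means these compounds.

In an ADME assay (on this read-out lower numbers stand for a shorter-lived compound and higher numbers for a longer-lived compound), compound 1 `COc1ccc(C[S+]([O-])c2ncccc2C(=O)Nc2ccncc2)c(OC)c1C` gives 0.12 h. Compound 2 `CCOc1cc(OC)ccc1C[S+]([O-])c1ncccc1C(=O)Nc1ccncc1` gives < 0.02 h, a limit and not a number, and so stands at the limit of < 0.02 h in this assay, at which 2 of the 3 values shown sit. Compound 3 `CCOc1ccc(C[S+]([O-])c2ncccc2C(=O)Nc2ccncc2)c(OCC)c1` gives < 0.02 h, also a limit.

Compound 4 `COCOc1cc(OC)ccc1C[S+]([O-])c1ncccc1C(=O)Nc1ccncc1` carries methoxy in place of methyl on a saturated chain carbon bound to an oxygen on an aromatic ring. For the measured compounds named here, the one measured change on that chain is a step that the two limits leave unreadable from compound 2 to compound 3, so it offers no size to carry over. The step expected in this assay is a step that the limit leaves unreadable from compound 2 to compound 4, with none expected beyond the scatter. The estimate for compound 4 is 0.015 h, with an expected range from 0.006 h to 0.04 h.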

Compound 4, half-life: < 0.02 h
Compound 4 ended at the assay's limit (the forecaster's own chance of this, stated with the estimate: 75%); the middle value is on the limit's open side.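

Compound 2 and compound 4 both stand at a limit, so no step between them can be read: the limit of < 0.02 h in this assay, at which 3 of the 4 values shown sit.

The compounds shown leave open whether methoxy in place of methyl on that chain alters the half-life in this assay at all.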